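Solubility notes: pyrrolidinyl replaces methoxyethylamino on the shared core

This account rests on a few compounds, and the source may have more. Where it says the series, first, only, none or still open, it means among the compounds named here.

Two compounds of the series have numbers in a physicochemical assay for solubility, with a stated time of 24 h, at pH 3; on this read-out lower numbers stand for lower solubility and higher numbers for higher solubility. Compound 1 `Cc1cc(-c2cnc(N3CCN(C)CC3)nc2-c2ccc(C)s2)on1` gives 11000 nM in this assay. Compound 2 `COCCNc1ncc(-c2cc(C)no2)c(C2CCN(C(C)=O)CC2)n1` gives 233000 nM in this assay, the higher of the two numbers, and the gap from compound 1 to compound 2 is wide enough to lie beyond the scatter. Compound 3 `CC(=O)N1CCC(c2nc(N3CCCC3)ncc2-c2cc(C)no2)CC1` has not been measured in this assay. It differs from compound 2 at one site: pyrrolidin-1-yl in place of (2-methoxyethyl)amino on an aromatic carbon. Among the measured compounds shown here, no measured pair isolates this change, so the expected step rests on these two compounds alone. The step from compound 2 to compound 3 is expected to be downward and modest, about a 2.9-fold lower number from compound 2 to compound 3 (0.46 log units; beyond the scatter), probably just beyond the scatter. For compound 3 the estimated value in this assay is 80000 nM, with a plausible range from 20000 nM to 250000 nM.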

Compound 3, solubility: 207000 nM
Estimate against measurement, compound 3: 2.6-fold (0.41 log units) below; measured number inside the range.
By their numbers in this assay, from the lowest: compound 1; then compounds 3 and 2 (each within the scatter of the next).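

In this assay, the step for pyrrolidin-1-yl in place of (2-methoxyethyl)amino on this aromatic carbon, between two ring nitrogen atoms, is a 1.1-fold lower number from compound 2 to compound 3 (0.05 log units; within the scatter) and gives this pair no order. At this position, the change from 1 hydrogen-bond donor and 2 hydrogen-bond acceptors to 0 hydrogen-bond donors and 1 hydrogen-bond acceptor, with the open chain replaced by a five-membered non-aromatic ring, therefore leaves the two numbers indistinguishable. No measurement at hand explains this match.

Still open, on these data alone, is whether a carboxylic acid, a primary amine or a longer ether chain on this same carbon would also stay within the scatter of compound 2. Also open, as far as these compounds go, is whether pyrrolidin-1-yl would give a similar step on the core of compound 1.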